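This account rests on a few compounds, and the source may have more. Where it says the series, first, only, none or still open, it means among the compounds named here.

Measured in a functional assay on CCRF-CEM cells (Homo sapiens) for cytotoxicity; a lower number here means a stronger inhibitor, a higher number a weaker inhibitor:
compound 1 `O=C(/C=C/C(=O)N1C/C(=C\c2ccccc2)C(=O)/C(=C/c2ccccc2)C1)Nc1ccc([N+](=O)[O-])cc1` gives 40000 nM
compound 2 `O=C(/C=C/C(=O)N1C/C(=C\c2ccc([N+](=O)[O-])cc2)C(=O)/C(=C/c2ccc([N+](=O)[O-])cc2)C1)Nc1ccc(Cl)c(Cl)c1` gives 380 nM

Compound 1 has the higher of the two numbers, and its gap to compound 2 is beyond the scatter; these two compounds differ in several places at once, so no single change can be read off from them. Compound 3 `Cc1ccc(NC(=O)/C=C/C(=O)N2C/C(=C\c3ccccc3)C(=O)/C(=C/c3ccccc3)C2)cc1` differs from compound 1 in one place only: methyl in place of nitro on an aromatic carbon. For the measured compounds named here, no measured pair shows this change, so the step is expected to be small, with no clear direction, at about a 2.0-fold lower number from compound 1 to compound 3 (0.30 log units; within the scatter). Compound 3 is estimated at 20000 nM, in the range 4000 nM to 80000 nM.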

Compound 3, half-maximal inhibitory concentration: 1100 nM
Compound 3: middle estimate off by 18-fold (1.26 log units), on the high side; the whole stated range lies above it.
By their numbers in this assay, from the lowest: compound 2; then compound 3; then compound 1.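

For the compounds shown here, replacing nitro with methyl on the aromatic ring gives a 36-fold lower number from compound 1 to compound 3 (1.56 log units; beyond the scatter) in this assay, the first step here that can be tied to one place. It shows that this position is far from neutral: a change of one group, with the rest of the molecule untouched, moves the number well beyond the scatter. Nothing shown here explains why.

On these data alone, whether methyl itself helps or nitro simply hurts stays open. So does how an amine, a carboxylic acid or a longer chain such as ethyl would behave at this position.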